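The compounds below may be only part of what the source reports. "The series", "measured", "known", "first", "only" and "open" are said of these compounds alone.

Measured so far in a functional assay for activation of Alpha-1A adrenergic receptor (Homo sapiens), read by calcium flux; on this read-out higher numbers stand for an effect only at larger amounts of compound and lower numbers for an effect already at smaller amounts:
- compound 1 `c1ccc(-c2cnccn2)c(OCC2=NCCN2)c1`: 2.51 nM
- compound 2 `c1ccc(-c2ccncn2)c(OCC2=NCCN2)c1`: a limit only, < 100000 nM
- compound 3 `c1csc(-c2ccccc2OCC2=NCCN2)c1`: 1 nM

Compound 3 holds the lowest of the two readable numbers in this assay. Within the data shown here, its only sized neighbour is compound 1, with a 2.5-fold lower number from compound 1 to compound 3 (0.40 log units; beyond the scatter). The steps a step that the limit leaves unreadable from compound 1 to compound 2 and a step that the limit leaves unreadable from compound 2 to compound 3 cannot be sized because of the limit of < 100000 nM in this assay, at which 1 of the 3 values shown sits.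

Compound 4 `c1c[nH]c(-c2ccccc2OCC2=NCCN2)c1` is not yet measured. Change: 1H-pyrrol-2-yl in place of thiophen-2-yl on an aromatic carbon. Among the measured compounds shown here, no measured step exchanges one five-membered ring for another; the readable step of a 2.5-fold lower number from compound 1 to compound 3 (0.40 log units; beyond the scatter) concerns a six-membered diazine replaced by thiophen-2-yl and bears only loosely on this change. A small to modest weakening is expected, a 3.0-fold higher number from compound 3 to compound 4 (0.48 log units; beyond the scatter). Compound 4 is estimated at 3 nM, expected between 0.6 nM and 20 nM.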

Compound 4, half-maximal effective concentration: 1.26 nM
For compound 4 the middle estimate is 2.4-fold (0.38 log units) above the measured one; measured number inside the range.
By their numbers in this assay, from the lowest: compounds 3, 4 and 1 (each within the scatter of the next, the first and the last beyond it).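

In this assay, placing 1H-pyrrol-2-yl for thiophen-2-yl on an aromatic carbon ortho to a group of 7 heavy atoms gives a 1.3-fold higher number from compound 3 to compound 4 (0.10 log units; within the scatter) and so shows that a five-membered ring carrying a hydrogen-bond donor is tolerated here. Set against pyrazin-2-yl, the same group gives a 2.0-fold lower number from compound 1 to compound 4 (0.30 log units; within the scatter) and so does not separate from it as thiophen-2-yl does. The step involving compound 2 cannot be read, as compound 2 has only a limit: the limit of < 100000 nM in this assay, at which 1 of the 4 values shown sits.

Still open, from the compounds shown here alone, is whether the ring hydrogen on nitrogen matters, as 1-methylpyrrol-2-yl would test. Also open, going by these compounds, is how a non-aromatic group such as an amine or a carboxylic acid behaves at this position.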